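The source may hold more compounds than are shown below. What is called first, only, known or untested is meant among the compounds shown, and "the series" means these compounds.

Of the compounds shown here, two have been measured. In a functional assay on HT-29 cells (Homo sapiens) for antiproliferative activity, read by MTT assay, with a stated time of 48 h (a lower number here means a stronger inhibitor, a higher number a weaker inhibitor), compound 1 `COc1ccc(N/C=C\C(=O)c2cn(-c3ccccc3)nc2-c2ccccc2)cc1` gives 1560 nM and compound 2 `O=C(/C=C\Nc1ccc(O)cc1)c1cn(-c2ccccc2)nc1-c1ccc(F)cc1` gives 1900 nM. On these two numbers compound 2 stands highest, with compound 1 nearest and the gap within the scatter. Compound 3 `COc1ccc(N/C=C\C(=O)c2cn(-c3ccccc3)nc2-c2ccc(F)cc2)cc1` differs from compound 2 by methyl in place of hydrogen on an oxygen on an aromatic ring, the hydroxy becoming methoxy on the (4-hydroxyphenyl)amino arm while the fluorine is kept. Since compound 1 carries the same methoxy group and gives 1560 nM, no step beyond the scatter is expected. The expected step reads a 1.3-fold lower number from compound 2 to compound 3 (0.10 log units; within the scatter). Compound 3 is estimated at 1500 nM in this assay, within a range of 700 nM to 3500 nM.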

Compound 3, half-maximal inhibitory concentration: 3200 nM
For compound 3 the middle estimate is 2.1-fold (0.33 log units) below the measured one; measured number inside the range.
By their numbers in this assay, from the lowest: compounds 1, 2 and 3 (each within the scatter of the next, the first and the last beyond it).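

In this assay, the hydroxy-to-methoxy change with the fluorine kept gives a 1.7-fold higher number from compound 2 to compound 3 (0.23 log units; within the scatter) and so cannot be told from the scatter at this oxygen. With the methoxy kept, fluoro in place of hydrogen on an aromatic carbon gives a 2.1-fold higher number from compound 1 to compound 3 (0.31 log units; beyond the scatter) as a modest step, the first in the series beyond the scatter. No supporting data bear on either step.

From the compounds shown here alone, whether chloro or trifluoromethyl on that aromatic carbon would behave like fluoro remains open. So does the effect of an ethoxy group or an amine in place of the methoxy.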